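The compounds below may be only part of what the source reports. "The series", "measured", "known", "first", "only" and "open" are said of these compounds alone.

Compound 1 `O=C(Nc1ccc(Cl)cc1)Nc1cccc(-c2nc(-c3ccc(NC(=O)c4cccnc4)cc3Cl)no2)c1` and compound 2 `C#Cc1cccc(NC(=O)Nc2cccc(-c3nc(-c4ccc(NC(=O)c5cccnc5)cc4Cl)no3)c2)c1` share one core and differ only at the urea-type nitrogen, where a 4-chlorophenyl or a 3-ethynylphenyl sits. In a functional assay on MDA-MB-231 cells (Homo sapiens) for antiproliferative activity, read by MTT assay, with a stated time of 72 h (a lower number here means a stronger inhibitor, a higher number a weaker inhibitor), compound 1 gives > 10000 nM, which is a limit of the assay and not a number. In this assay compound 2 likewise gives > 10000 nM, again a limit rather than a measured number. The step that the two limits leave unreadable from compound 1 to compound 2 therefore cannot be read in size or direction, since both values rest at the limit of > 10000 nM in this assay, at which 2 of the 2 values shown sit. Among the measured compounds shown here, compound 2 thus stands only at a limit; the one further value shown beside it is a limit as well, so no ranking within the pair is possible.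

Compound 3 `NS(=O)(=O)Nc1ccc(NC(=O)Nc2cccc(-c3nc(-c4ccc(NC(=O)c5cccnc5)cc4Cl)no3)c2)cc1` carries the change (4-(sulfamoylamino)phenyl in place of 3-ethynylphenyl on an amide-type nitrogen). For the measured compounds named here, the only measured step that bears on this position is the unreadable one from compound 1 to compound 2, so no readable size is available to guide an expectation for this assay. Compound 3 is expected at 15000 nM with a range 3000 nM to 60000 nM, most likely again reported only as a limit. This corresponds to an expected step that the limit leaves unreadable from compound 2 to compound 3.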

Compound 3, half-maximal inhibitory concentration: 8900 nM
Compound 3: middle estimate off by 1.7-fold (0.23 log units), on the high side; the measured number falls inside the stated range.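

In this assay, among the compounds shown here, compound 3 gives 8900 nM, the first value on this amide-type nitrogen that is a number and not a limit, so this substituent position can yield a readable result on the shared core. Replacing 3-ethynylphenyl with 4-(sulfamoylamino)phenyl gives an at least 1.1-fold lower number from compound 2 to compound 3 (0.05 log units; that floor lies within the scatter), and sulfamoylamino in place of chloro on an aromatic carbon gives an at least 1.1-fold lower number from compound 1 to compound 3 (0.05 log units; that floor lies within the scatter). Both comparisons remain one-sided, with a floor on each step and no measured size: the limit of > 10000 nM in this assay, at which 2 of the 3 values shown sit.

The compounds shown leave open whether the value of compound 3 depends on the sulfamoylamino group as such or would also be reached with other groups on the phenyl ring. A 4-aminophenyl or a 4-carboxyphenyl on the same amide-type nitrogen would test an amine and a carboxylic acid in this role, and a longer chain carrying the sulfamoylamino group would show whether its distance from the phenyl ring affects the read-out.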